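Two Methyls at the Acid End: Expectation for Compound 4

The source may report more compounds than this note shows. Statements on the series, on what has been measured and on what is new or still open speak of the compounds shown alone.

In an assay for binding affinity to leukotriene B4 receptor 1 (Homo sapiens) (a lower number here means a stronger inhibitor, a higher number a weaker inhibitor), the measured compounds stand as follows:
compound 1, `O=C(O)CCCCCOc1cc(-c2ccccc2)cc(-c2ccccc2)n1`: 30 nM
compound 2, `CC(CCCCOc1cc(-c2ccccc2)cc(-c2ccccc2)n1)C(=O)O`: 30 nM
compound 3, `O=C(O)CCCCCCOc1cc(-c2ccccc2)cc(-c2ccccc2)n1`: 15 nM

Compound 3 has the lowest of the three numbers, yet a 2.0-fold lower number from compound 1 to compound 3 (0.30 log units; within the scatter) and a 2.0-fold lower number from compound 2 to compound 3 (0.30 log units; within the scatter), so nothing separates the three compounds in this assay; they sit within one another's scatter.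

Compound 4, `CC(C)(CCCCCCOc1cc(-c2ccccc2)cc(-c2ccccc2)n1)C(=O)O`, differs from compound 3 by 1-carboxy-1-methylethyl in place of carboxy on a saturated chain carbon, six bonds along the chain from an oxygen on an aromatic ring. The measured step that bears most directly on this change is no change at the digits printed from compound 1 to compound 2 (within the scatter): a single methyl on the saturated chain carbon bound to the carbonyl carbon left the number where it was. Compound 4 carries two such methyls on a chain that is one carbon longer, and a 2.0-fold lower number from compound 1 to compound 3 (0.30 log units; within the scatter) shows that the extra chain length on its own also moved the number only within the scatter. The second methyl goes one step beyond anything measured here, so some uncertainty remains.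

Compound 4 is therefore expected to show a 1.3-fold higher number from compound 3 to compound 4 (0.12 log units; within the scatter), that is, no step beyond the scatter in either direction. The estimate for compound 4 is 20 nM, with a range from 7 nM to 60 nM.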

Compound 4, half-maximal inhibitory concentration: 60 nM
Compound 4: middle estimate off by 3.0-fold (0.48 log units), on the low side; the measured number falls inside the stated range.
By their numbers in this assay, from the lowest: compounds 3, 1, 2 and 4 (each within the scatter of the next, the first and the last beyond it).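

In this assay, within the data shown here, the change from carboxy to 1-carboxy-1-methylethyl, on a saturated chain carbon six bonds along the chain from an oxygen on an aromatic ring, gives a 4.0-fold higher number from compound 3 to compound 4 (0.60 log units; beyond the scatter) and so separates two compounds for the first time. That separation holds against compound 3 alone: the other comparisons read a 2.0-fold higher number from compound 2 to compound 4 (0.30 log units; within the scatter) and a 2.0-fold higher number from compound 1 to compound 4 (0.30 log units; within the scatter) and leave compound 4 inseparable from both. A single methyl had given no change at the digits printed from compound 1 to compound 2 (within the scatter) while the pair of methyls on the longer chain now shows a step beyond the scatter, so this position does respond to the change, though modestly.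

Nothing at hand accounts for this step. The compounds shown leave open whether a single methyl on the chain of compound 3 would already give such a step, and how a cyclopropane ring carrying the carboxylic acid, or a tetrazole in its place, would read.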